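Fluoromethyl on the carbamate of the pyrazine sulfone pair

This account rests on a few compounds, and the source may have more. Where it says the series, first, only, none or still open, it means among the compounds named here.

Measured so far in a functional assay on isolated protein for agonist activity at Glucose-dependent insulinotropic receptor (Rattus norvegicus), read by HTRF and cAMP accumulation; on this read-out lower numbers stand for smaller maximal responses and higher numbers for larger maximal responses:
compound 1, `CC(C)OC(=O)N1CCC(O[C@H]2CC[C@H](Oc3ccc(S(C)(=O)=O)nc3)CC2)CC1` — compound 1 gives 125%
compound 2, `CC(C)OC(=O)N1CCC(O[C@H]2CC[C@H](Oc3cnc(S(C)(=O)=O)cn3)CC2)CC1` — compound 2 gives 120%

Among the measured compounds shown here, the only measured step is a number 5 percentage points lower from compound 1 to compound 2 (within the scatter), so compound 2 and compound 1 cannot be told apart on this read-out. Compound 3, `C[C@@H](CF)OC(=O)N1CCC(O[C@H]2CC[C@H](Oc3cnc(S(C)(=O)=O)cn3)CC2)CC1`, differs from compound 2 by fluoro in place of hydrogen on a saturated chain carbon, two bonds along the chain from an oxygen next to a carbonyl group. For the measured compounds named here, no measured step touches the carbamate side of the shared core; the one step known concerns the aryl ether and does not bear on this change. With nothing to suggest a shift, the step of no change at the digits printed from compound 2 to compound 3 (within the scatter) is expected to stay within the scatter. Compound 3 is therefore estimated at 120%, between 100% and 140%.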

Compound 3, largest response reached (Emax), in percent of the reference or control that the assay uses: 123%
For compound 3 the middle estimate is 3 percentage points below the measured one; the range from low to high includes it.
By their numbers in this assay, from the lowest: compounds 2, 3 and 1 (each within the scatter of the next).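

In this assay, among the compounds shown here, the change on the carbamate side of the shared core reads a number 3 percentage points higher from compound 2 to compound 3 (within the scatter) and so gives no step that can be told from the scatter. On this read-out, 1-(fluoromethyl)ethyl can stand in place of isopropyl, so this saturated chain carbon accepts a fluoro. No further data on hand bear on this result.

As far as these compounds go, whether an amine, a carboxylic acid or a longer chain on this carbon would hold the response remains open. So does whether fluoro in this place reads the same with the 6-(methylsulfonyl)pyridin-3-yl group of compound 1.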